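This account rests on a few compounds, and the source may have more. Where it says the series, first, only, none or still open, it means among the compounds named here.

All three measured compounds were tested in an assay for inhibition of Fatty-acid amide hydrolase 1 (Homo sapiens), tested at 1 mM; on this read-out higher numbers stand for more inhibition at the one concentration tested (going by the name of the read-out) and lower numbers for less inhibition:

compound 1, `C=CCCC1CN([Si](C)(C)C(C)(C)C)C1=O`, gives 49.5%
compound 2, `C=CCCC(=O)N1CC(CC=C)C1=O`, gives 96.5%
compound 3, `C=CCC1CNC1=O`, gives 56.6%

Compound 1 stands lowest of the three numbers in this assay. Its nearest neighbour is compound 3, whose number lies within the usual scatter of this kind of measurement, so the two cannot be told apart. Compound 2 lies well beyond the scatter above compound 1, and is the only one of the three that clearly separates from it.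

Compound 4, `C=CCC1CN([Si](C)(C)C(C)(C)C)C1=O`, has not yet been measured. It differs from compound 1 in one place: vinyl in place of allyl on a saturated chain carbon bound to a saturated ring carbon. Within the data shown here, no pair of measured compounds differs in exactly this way, so there is no measured step to lean on. Compound 1 and compound 3 differ in more than one place, and their numbers sit within the scatter of each other, which gives no hint of a direction.

With that in mind, the step of a number 3.5 percentage points lower from compound 1 to compound 4 (within the scatter) is expected to stay within the scatter, in no particular direction. Compound 4 is therefore estimated at 46%, with a range from 22% to 70%.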

Compound 4, a percentage reported as inhibition, at one concentration (the size of the read-out at that concentration, not a potency): 43.6%
Estimate against measurement, compound 4: 2.4 percentage points above; low and high end bracket the measured number.
By their numbers in this assay, from the lowest: compounds 4, 1 and 3 (each within the scatter of the next, the first and the last beyond it); then compound 2.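

Among these compounds, the new result gives the first direct comparison at this position: in this assay, vinyl in place of allyl on a saturated chain carbon bound to a saturated ring carbon gives a number 5.9 percentage points lower from compound 1 to compound 4 (within the scatter) on an otherwise unchanged structure. In this one pair, then, going from 3 heavy atoms to 2 in this unsaturated group does not separate the two compounds, and the same holds for the change read as but-3-en-1-yl to allyl. No measurement shown offers an explanation for this step.

Still open, going by these compounds, is whether a longer chain, an amine or a carboxylic acid at this place would give a number beyond the scatter. Also open, on these data alone, is whether vinyl in place of allyl would read the same way on the core of compound 2.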